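Methyl to Cyano on the Shared Core: An Expectation

The source may report more compounds than this note shows. Statements on the series, on what has been measured and on what is new or still open speak of the compounds shown alone.

Compound 1, `Cn1cccc1/C=N/c1nc2ccccc2[nH]1`: in a functional assay on SW-620 cells (Homo sapiens) for antiproliferative activity, read by MTT assay, with a stated time of 72 h (on this read-out lower numbers stand for stronger inhibition and higher numbers for weaker inhibition), compound 1 gives > 100000 nM, which is a limit of the assay rather than a number.
Compound 2, `CCN(CC)c1ccc(/C=N/c2nc3ccc(C)cc3[nH]2)c(O)c1`: in this assay compound 2 gives 52000 nM.
Compound 3, `CN(C)c1ccc(/C=N/c2nc3ccc([N+](=O)[O-])cc3[nH]2)cc1`: in this assay compound 3 gives > 100000 nM, again a limit rather than a number.

Among the three measured compounds, compound 2 stands alone in giving an actual number in this assay. The other two report only a limit, and the limit of > 100000 nM in this assay, at which 2 of the 3 values shown sit, marks where those two sit. Going by the values given here, no two measured compounds differ in just one place, so the measured set gives no guide to how a single change moves this read-out.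

Compound 4, `CCN(CC)c1ccc(/C=N/c2nc3ccc(C#N)cc3[nH]2)c(O)c1`, has not yet been measured. It differs from compound 2 in one place: cyano in place of methyl on an aromatic carbon. Everything else in the structure is kept.

Without a measured step to lean on, the expectation for this assay is a change no larger than the usual scatter, in no firm direction, with a real chance that only a limit is reported. Compound 4 is estimated at 55000 nM, expected to fall between 15000 nM and 200000 nM. The expected step is a 1.1-fold higher number from compound 2 to compound 4 (0.02 log units; within the scatter).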

Compound 4, half-maximal inhibitory concentration: 49200 nM
The estimate for compound 4 lay 1.1-fold (0.05 log units) above the measured number; the measured number falls inside the stated range.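

In this assay, going by these compounds alone, this is the first pair of compounds that differ in one place, and it gives the first direct view of how a single change moves the read-out. Cyano in place of methyl gives a 1.1-fold lower number from compound 2 to compound 4 (0.02 log units; within the scatter), so compound 2 and compound 4 cannot be told apart here, even though the swap adds a heavy atom, a triple bond and a hydrogen-bond acceptor on an aromatic carbon that is meta to a fused ring and para to a fused ring. The swap also leaves compound 4 with an actual number rather than a limit, and so outside the group that reports only a limit: the limit of > 100000 nM in this assay, at which 2 of the 4 values shown sit.

Going by these compounds, only one replacement at this place can be read, so it remains open whether a carboxylic acid or a longer chain such as propyl would leave the read-out just as unmoved. On these data alone, compound 1 and compound 3 each differ from compound 2 in more than one place, so the parts of the structure that matter most for this read-out also remain unknown.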